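Shrinking the Saturated Ring on a Shared Core

The source may hold more compounds than are shown below. What is called first, only, known or untested is meant among the compounds shown, and "the series" means these compounds.

Compound 1 `CC(=O)N1CC=C(c2ccn3c(-c4ccc(NC(=O)c5ccc([N+](=O)[O-])o5)cc4)cnc3c2)CC1` gives 410 nM in a functional assay on AGS cells (Homo sapiens) for antiproliferative activity, read by CCK-8 assay, with a stated time of 72 h; a lower number here means a stronger inhibitor, a higher number a weaker inhibitor.
Compound 2 `CN1CCN(c2ccn3c(-c4ccc(NC(=O)c5ccc([N+](=O)[O-])o5)cc4)cnc3c2)CC1` gives 2340 nM in this assay.
Compound 3 `O=C(Nc1ccc(-c2cnc3cc(N4CCCC4)ccn23)cc1)c1ccc([N+](=O)[O-])o1` gives 1240 nM in this assay.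

Compound 3 holds the second highest of the three numbers: compound 2 sits close to it, within the scatter, while compound 1 lies further off, beyond the scatter. Compound 4 `O=C(Nc1ccc(-c2cnc3cc(N4CCC4)ccn23)cc1)c1ccc([N+](=O)[O-])o1` carries azetidin-1-yl in place of pyrrolidin-1-yl on an aromatic carbon. Going by the values given here, two measured steps bear on this change. The step of a 3.0-fold higher number from compound 1 to compound 3 (0.48 log units; beyond the scatter) accompanied a move from a six-membered non-aromatic ring to a five-membered one, whereas a 1.9-fold lower number from compound 2 to compound 3 (0.28 log units; within the scatter) stayed within the scatter. A further shrinking of the ring is therefore expected to bring at most a modest rise, a 1.5-fold higher number from compound 3 to compound 4 (0.16 log units; within the scatter). Compound 4 is estimated at 1800 nM, within a range from 700 nM to 4500 nM.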

Compound 4, half-maximal inhibitory concentration: > 5000 nM
Compound 4 was reported as a limit (the forecaster's own chance of this, stated with the estimate: 5%); middle value at least 2.7-fold (0.44 log units) from the limit.
By their numbers in this assay, from the lowest: compound 1; then compounds 3 and 2 (each within the scatter of the next). At a limit, above all of these: compound 4.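

In this assay compound 4 stands only as a limit of the assay, not as a number: the limit of > 5000 nM in this assay, at which 1 of the 4 values shown sits. At this position, opposite the ring nitrogen, azetidin-1-yl in place of pyrrolidin-1-yl gives an at least 4.0-fold higher number from compound 3 to compound 4 (0.60 log units; beyond the scatter) and so shows a step beyond the scatter, which the change from 4-methylpiperazin-1-yl to pyrrolidin-1-yl did not. The limit also separates compound 4 from the other two, with an at least 2.1-fold higher number from compound 2 to compound 4 (0.32 log units; beyond the scatter) and with an at least 12-fold higher number from compound 1 to compound 4 (1.08 log units; beyond the scatter) as the large step.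

As far as these compounds go, the true size of these steps stays open. So does whether an open-chain dimethylamino group or a morpholin-4-yl ring would hold activity here.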